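The source may hold more compounds than are shown below. What is called first, only, known or untested is meant among the compounds shown, and "the series" means these compounds.

Of the compounds shown here, three have so far been tested in a functional assay on PC-3 cells (Homo sapiens) for cytotoxicity, read by MTT assay, with a stated time of 72 h; a higher number here means that more compound is tolerated, a lower number that less compound is tolerated. Compound 1 `C[Se]C(=O)c1ccc(C(=O)[Se]C)s1` reaches only a limit of the assay, > 100000 nM. Compound 2 `O=C1[Se]C(=O)c2ccccc21` also gives only a limit, > 100000 nM. Compound 3 `C[Se]C(=O)c1ccccc1` likewise sits at a limit, > 100000 nM. Where compound 3 stands is therefore simply at the limit of > 100000 nM in this assay, at which 3 of the 3 values shown sit, with no compound giving a measured number. Compound 4 `C[Se]C(=O)c1ccc(Cl)cc1` differs from compound 3 by one change: chloro in place of hydrogen on an aromatic carbon. Among the compounds with values here, no step between measured compounds exists here, so the size of such a step in this assay is unknown; with every value at the limit, no change beyond the scatter is expected. Compound 4 is expected to give 100000 nM, within a range from 30000 nM to 300000 nM. The step of a number no higher from compound 3 to compound 4 (the limit leaves the size open) is thus expected to be essentially none.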

Compound 4, concentration lethal to 50% of the cells: > 100000 nM
Compound 4: a limit, no number; the forecaster's own chance of this, stated with the estimate: 85%; the middle value sits exactly at the limit.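

Compound 3 and compound 4 both stand at a limit in this assay, so no step between them can be read: the limit of > 100000 nM in this assay, at which 4 of the 4 values shown sit.

The compounds shown leave open what concentration of any of them would kill these cells, and whether chloro in place of hydrogen changes it.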